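The source may report more compounds than this note shows. Statements on the series, on what has been measured and on what is new or still open speak of the compounds shown alone.

Measured compounds in a functional assay on HCT-116 cells (Homo sapiens) for cytotoxicity, read by MTT assay, with a stated time of 48 h; a lower number here means a stronger inhibitor, a higher number a weaker inhibitor:
compound 1, `COc1ccc(NC(=O)c2cn(-c3ccccc3)nc2-c2ccc(C)cc2)cc1`: compound 1 gives 1450 nM
compound 2, `CCOc1ccc(NC(=O)c2cn(-c3ccccc3)nc2-c2ccc(C)cc2)cc1`: compound 2 gives 780 nM
compound 3, `COc1ccc(NC(=O)c2cn(-c3ccccc3)nc2-c2ccc(OC)cc2)cc1`: compound 3 gives 1520 nM

Compound 1 and compound 2 differ in one place, (methyl in place of hydrogen on a saturated chain carbon bound to an oxygen on an aromatic ring), and this change made a step of a 1.9-fold lower number from compound 1 to compound 2 (0.27 log units; within the scatter). Compound 1 and compound 3 differ in another place, (methoxy in place of methyl on an aromatic carbon), and here the step was a 1.0-fold higher number from compound 1 to compound 3 (0.02 log units; within the scatter). Compound 3 stands within the scatter of compound 1 and of compound 2, so no order among the three can be read from these numbers.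

The unmeasured compound 4, `CCOc1ccc(NC(=O)c2cn(-c3ccccc3)nc2-c2ccc(OC)cc2)cc1`, carries the change methyl in place of hydrogen on a saturated chain carbon bound to an oxygen on an aromatic ring on the core of compound 3. This is the same change as the one from compound 1 to compound 2: the place reads the same word for word in both cases, on a saturated chain carbon bound to an oxygen on an aromatic ring, and the change occurs twice among the compounds shown. The cores differ only by methoxy in place of methyl on an aromatic carbon.

Because the earlier step of this change was a 1.9-fold lower number from compound 1 to compound 2 (0.27 log units; within the scatter), a step of similar size is expected from compound 3 to compound 4, namely a 1.8-fold lower number from compound 3 to compound 4 (0.25 log units; within the scatter), though a step of that size stays within the scatter and could in practice come out flat. Compound 4 is therefore estimated at 850 nM in this assay, with a plausible range from 400 nM to 1800 nM.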

Compound 4, half-maximal inhibitory concentration: 970 nM
Compound 4: the middle estimate sits 1.1-fold (0.06 log units) below what was measured, within the range that was stated.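

In this assay, replacing methoxy with ethoxy on the core of compound 3 gave a 1.6-fold lower number from compound 3 to compound 4 (0.20 log units; within the scatter), and this step agrees with the one seen earlier for the same change on the core of compound 1: the same change on two cores in this assay, a 1.9-fold lower number (0.27 log units; within the scatter) from compound 1 to compound 2 and a 1.6-fold lower number (0.20 log units; within the scatter) from compound 3 to compound 4, 1.2-fold (0.07 log units) apart, within the scatter of two such steps. The second change, methoxy in place of methyl on an aromatic carbon, gave a 1.2-fold higher number from compound 2 to compound 4 (0.09 log units; within the scatter), and it likewise agrees with its earlier step: the same change on two cores in this assay, a 1.0-fold higher number (0.02 log units; within the scatter) from compound 1 to compound 3 and a 1.2-fold higher number (0.09 log units; within the scatter) from compound 2 to compound 4, 1.2-fold (0.07 log units) apart, within the scatter of two such steps. Both changes therefore carried from one core to the other without a readable difference, but each step lies within the scatter, so the four compounds do not show that either change has a real effect in this assay, and agreement among such small steps is weak evidence that the changes add up independently.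

The compounds shown leave open whether a longer chain, such as propoxy or butoxy, or an amine at the end of that chain would give a step beyond the scatter. They also leave open whether a step of that larger size would carry between cores as closely as these small ones did.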